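The compounds below may be only part of what the source reports. "The series", "measured", "known", "first", "only" and "open" are said of these compounds alone.

Measured compounds in a functional assay on HL-60 cells (Homo sapiens) for antiproliferative activity, read by XTT assay, with a stated time of 72 h; on this read-out higher numbers stand for weaker inhibition and lower numbers for stronger inhibition:
- compound 1 `COc1ncnc2c1c(I)cn2[C@@H]1O[C@H](CO)[C@@H](O)[C@H]1O` gives 2300 nM
- compound 2 `Nc1nc2c(c(-c3ccccc3)cn2[C@@H]2O[C@H](CO)[C@@H](O)[C@H]2O)c(=O)[nH]1` gives only a limit, > 20000 nM
- compound 3 `O=c1[nH]cnc2c1c(-c1ccsc1)cn2[C@@H]1O[C@H](CO)[C@@H](O)[C@H]1O` gives 12000 nM

Compound 1 holds the lowest of the two numbers obtained in this assay; compound 3 stands a good deal higher, beyond the usual scatter, while compound 2 reaches no number at all but only the limit described by the limit of > 20000 nM in this assay, at which 1 of the 3 values shown sits. Within the data shown here, the two compounds that differ from compound 1 in more than one place, compound 2 and compound 3, cannot be read as single steps, so their values say only that the shared core, when built out differently, can land far weaker.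

Compound 4 `COc1ncnc2c1c(-c1ccoc1)cn2[C@@H]1O[C@H](CO)[C@@H](O)[C@H]1O` has not yet been measured in this assay. Its change from compound 1 is furan-3-yl in place of iodo on an aromatic carbon. Among the measured compounds shown here, no step between measured compounds tracks this change, so any expectation rests on the spread of the three values alone. Since compound 1 gives 2300 nM and is the stronger of the two numbers, compound 4 is expected to stay near it, with the step of a 1.5-fold lower number from compound 1 to compound 4 (0.19 log units; within the scatter) estimated to lie within or only modestly beyond the scatter. The estimate for compound 4 in this assay is 1500 nM, with a range from 300 nM to 8000 nM.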

Compound 4, half-maximal inhibitory concentration: 150 nM
Estimate against measurement, compound 4: 10-fold (1.00 log units) above, outside the stated range (below it).
By their numbers in this assay, from the lowest: compound 4; then compound 1; then compound 3. At a limit, above all of these: compound 2.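

In this assay, furan-3-yl in place of iodo gives a 15-fold lower number from compound 1 to compound 4 (1.19 log units; beyond the scatter), the only step shown that changes a single place. It shows that this aromatic carbon, two ring bonds from the ring nitrogen, accepts a five-membered aromatic ring of 5 heavy atoms in place of a single iodine, and that the change brings far stronger inhibition rather than the loss that the weaker ring-bearing compounds might have suggested. Compound 2 and compound 3 also carry a ring at this place but differ from compound 4 in more than one place, so no steps can be read from them, and nothing measured here accounts for the size of the gain.

The compounds shown leave open whether the gain belongs to furan-3-yl itself or would also appear with a phenyl or thiophen-3-yl group at this carbon while the methoxy group stays in place. They also leave open how this assay would respond if an amine or a methyl group replaced that methoxy group with furan-3-yl kept.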